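The source may hold more compounds than are shown below. What is called first, only, known or untested is meant among the compounds shown, and "the series" means these compounds.

Compound 1, `Cc1cnn(C(=O)N2CCCCC2)c1`, and compound 2, `O=C(N1CCCCC1)n1cccn1`, share a small core, while compound 3, `Cc1cnn(C(=O)N2CCN(C(c3ccc4ccccc4c3)c3ccc4ccccc4c3)CC2)c1`, and compound 4, `O=C(N1CCN(C(c2ccc3ccccc3c2)c2ccc3ccccc3c2)CC1)n1cccn1`, carry a much larger group on the same kind of ring. In an assay on membranes from brain for binding affinity to Monoglyceride lipase (Mus musculus), read by fluorescence, with stated times of 1 h and 30 min (a lower number here means a stronger inhibitor, a higher number a weaker inhibitor), compound 1 gives 9200 nM. Compound 2 is made from it by hydrogen in place of methyl on an aromatic carbon, and a 1.4-fold lower number from compound 1 to compound 2 (0.14 log units; within the scatter). In this assay compound 2 gives 6600 nM. In this assay compound 3 gives 260 nM. How the core of compound 1 and the core of compound 3 differ is not broken down here. Compound 4 has not been measured yet; it differs from compound 3 by hydrogen in place of methyl on an aromatic carbon. This is the same kind of change as that from compound 1 to compound 2, but not the same: in compound 3 the ring atom bears a large group, whereas in compound 1 it bears a group of 8 heavy atoms. For compound 4 in this assay a step of a 1.3-fold lower number from compound 3 to compound 4 (0.11 log units; within the scatter) is expected, because a 1.4-fold lower number from compound 1 to compound 2 (0.14 log units; within the scatter) stayed within the scatter, and the estimate for compound 4 is 200 nM, most likely between 80 nM and 500 nM.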

Compound 4, half-maximal inhibitory concentration: 1800 nM
Beside the measured number, compound 4's estimate is 9.0-fold (0.95 log units) below it, and the stated range ends below it.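

On the large core, the change from 4-methyl-1H-pyrazol-1-yl to 1H-pyrazol-1-yl gives in this assay a 6.9-fold higher number from compound 3 to compound 4 (0.84 log units; beyond the scatter), so a step seen on the small core cannot simply be carried over to the large one, and the two cores clearly part here: the same change on two cores in this assay, a 1.4-fold lower number (0.14 log units; within the scatter) from compound 1 to compound 2 and a 6.9-fold higher number (0.84 log units; beyond the scatter) from compound 3 to compound 4, 9.7-fold (0.98 log units) apart, beyond the scatter of two such steps The methyl on this aromatic carbon therefore matters on the core of compound 3, while its loss on the core of compound 1 stays within the scatter. This rests on a single pair for each core, and it shows neither why the two cores respond differently nor how the change would behave on a third core.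

The compounds shown carry only methyl or hydrogen on this carbon, leaving open whether an ethyl group, a chlorine atom or a methoxy group there would read like compound 3 or like compound 4. Going by these compounds alone, also open is which part of the large group goes with the shift in numbers between the two cores, as no single-change steps connect them.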